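This account rests on a few compounds, and the source may have more. Where it says the series, first, only, none or still open, it means among the compounds named here.

Compound 1 `NC(=O)CNC[C@@H]1CCCc2cc(S(=O)(=O)c3cccc(F)c3)ccc21`: in an assay on isolated protein for displacement of a labelled ligand from 5-hydroxytryptamine receptor 6 (Homo sapiens) (on this read-out higher numbers stand for weaker inhibition and lower numbers for stronger inhibition), compound 1 gives 0.1 nM.
Compound 2 `CNC(=O)NC[C@@H]1CCCc2cc(S(=O)(=O)c3cccc(F)c3)ccc21`: in this assay compound 2 gives 0.398 nM.

Compound 2 stands at the higher of the two numbers, separated from compound 1 by a 4.0-fold higher number from compound 1 to compound 2 (0.60 log units; beyond the scatter). Compound 3 `CC(=O)N(C)C[C@@H]1CCCc2cc(S(=O)(=O)c3cccc(F)c3)ccc21` differs from compound 2 by acetyl(methyl)amino in place of (methylcarbamoyl)amino on a saturated chain carbon bound to a saturated ring carbon. Going by the values given here, the only measured step, from compound 1 to compound 2, touches the same substituent but a different part of it, and it was modest; nothing measured tracks the present change directly. Compound 3 is therefore expected to show a small step, a 1.8-fold higher number from compound 2 to compound 3 (0.25 log units; within the scatter), toward a higher number. The estimate for compound 3 is 0.7 nM, within 0.15 nM to 3.5 nM.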

Compound 3, inhibition constant: 1.59 nM
Compound 3: the middle estimate sits 2.3-fold (0.36 log units) below what was measured; the range from low to high includes it.
By their numbers in this assay, from the lowest: compound 1; then compound 2; then compound 3.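

Replacing (methylcarbamoyl)amino, which has 2 hydrogen-bond donors, with acetyl(methyl)amino, which has 0 hydrogen-bond donors, gives a 4.0-fold higher number from compound 2 to compound 3 (0.60 log units; beyond the scatter), a second step beyond the scatter at this substituent. Taken together, the changes at this place span a 16-fold higher number from compound 1 to compound 3 (1.20 log units; beyond the scatter), the widest gap among the three compounds in this assay. Nothing shown bears on the reason for these steps. The compounds shown leave open whether the donor count or the rearranged atoms track the numbers, and how a plain amine or a longer chain on this saturated chain carbon would read.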